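From an Ether Side Chain to a Cyclohexyl Ring

The source may hold more compounds than are shown below. What is called first, only, known or untested is meant among the compounds shown, and "the series" means these compounds.

Compound 1 `CCCOCCNC1=Nc2ccccc2C(C)N1` gives 241 nM in an assay on isolated protein for binding affinity to 5-hydroxytryptamine receptor 5A (Homo sapiens); a lower number here means a stronger inhibitor, a higher number a weaker inhibitor.
Compound 2 `CCOCCCNC1=Nc2ccccc2C(C)N1` gives 176 nM in this assay.
Compound 3 `CC1NC(NCC2COCCO2)=Nc2ccccc21` gives 96 nM in this assay.

Compound 2 stands second highest of the three numbers. Its nearest neighbour is compound 1: a 1.4-fold lower number from compound 1 to compound 2 (0.14 log units; within the scatter). Its furthest neighbour is compound 3: a 1.8-fold lower number from compound 2 to compound 3 (0.26 log units; within the scatter). Among the measured compounds shown here, the only step among the measured compounds that goes beyond the scatter is a 2.5-fold lower number from compound 1 to compound 3 (0.40 log units; beyond the scatter).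

Compound 4 `CC1NC(NCCC2CCCCC2)=Nc2ccccc21` is the next compound to be tested. It differs from compound 2 in one place: cyclohexyl in place of ethoxymethyl on a saturated chain carbon, two bonds along the chain from an amine nitrogen. None of the three measured steps bears closely on this change. Each of them keeps an oxygen in the side chain and only moves it or folds it into a second ring, whereas compound 4 loses the oxygen of compound 2 altogether and gains a ring of carbon only. The measured steps were all small, and the change from compound 2 to compound 4 is larger than any of them. The step of a 1.5-fold higher number from compound 2 to compound 4 (0.17 log units; within the scatter) is therefore estimated with wide uncertainty, leaning toward a somewhat higher number. Compound 4 is expected to give 260 nM in this assay, with a range from 80 nM to 850 nM.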

Compound 4, inhibition constant: 124 nM
Compound 4: middle estimate off by 2.1-fold (0.32 log units), on the high side; low and high end bracket the measured number.
By their numbers in this assay, from the lowest: compounds 3, 4, 2 and 1 (each within the scatter of the next, the first and the last beyond it).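

In this assay, cyclohexyl in place of ethoxymethyl on a saturated chain carbon, two bonds along the chain from an amine nitrogen, gives a 1.4-fold lower number from compound 2 to compound 4 (0.15 log units; within the scatter), and cyclohexyl in place of propoxy at that same place gives a 1.9-fold lower number from compound 1 to compound 4 (0.29 log units; within the scatter). Among the compounds shown here, every earlier compound kept oxygen in its side chain, so compound 4 is the first to show that a ring of carbon only, with no hydrogen-bond acceptor in the entering group, can stand at this position without a step beyond the scatter from either compound 2 or compound 1. Nothing on hand accounts for this result, and the reason for it stays unknown.

The compounds shown leave open whether the ring itself matters at this position, which an open hexyl chain or a phenyl ring in the same place could help to settle. They also leave open how the number would respond to a charged group there, such as an amine or a carboxylic acid on the chain.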